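Benzyloxy aryl variation on the shared core: towards compound 4

The source may hold more compounds than are shown below. What is called first, only, known or untested is meant among the compounds shown, and "the series" means these compounds.

Measured in a functional assay on MCF7 cells (Homo sapiens) for antiproliferative activity, read by sulforhodamine B assay, with a stated time of 72 h; on this read-out higher numbers stand for weaker inhibition and lower numbers for stronger inhibition:
compound 1 `Cc1cccc(COc2ccc(-c3cc(CN4CCN(Cc5ccc(C(F)(F)F)cc5)CC4)no3)cc2)c1`: 4000 nM
compound 2 `N#Cc1ccc(COc2ccc(-c3cc(CN4CCN(Cc5ccc(C(F)(F)F)cc5)CC4)no3)cc2)cc1`: 100 nM
compound 3 `COc1ccc(COc2ccc(-c3cc(CN4CCN(Cc5ccc(C(F)(F)F)cc5)CC4)no3)cc2)cc1`: 1300 nM

Compound 3 stands second highest of the three numbers. The two steps that reach it are a 3.1-fold lower number from compound 1 to compound 3 (0.49 log units; beyond the scatter) and a 13-fold higher number from compound 2 to compound 3 (1.11 log units; beyond the scatter); the third step in the set is a 40-fold lower number from compound 1 to compound 2 (1.60 log units; beyond the scatter). All three changes sit on the same saturated chain carbon bound to an oxygen on an aromatic ring, and each moves the number beyond the scatter, so this place is sensitive.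

Compound 4 `COc1cc(COc2ccc(-c3cc(CN4CCN(Cc5ccc(C(F)(F)F)cc5)CC4)no3)cc2)cc(OC)c1OC` differs from compound 3 in one place: 3,4,5-trimethoxyphenyl in place of 4-methoxyphenyl on a saturated chain carbon bound to an oxygen on an aromatic ring. Among the measured compounds shown here, no measured step changes the count of methoxy groups on this ring, so none bears directly on it; the nearest guide is the pair of compound 3 and compound 1, which shows that a single substituent swap here already gives a modest step. A step of similar size is expected, taken towards a lower number, as a 1.9-fold lower number from compound 3 to compound 4 (0.27 log units; within the scatter). Compound 4 is therefore estimated at 700 nM, within a range of 150 nM to 3000 nM.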

Compound 4, half-maximal inhibitory concentration: 1800 nM
Estimate against measurement, compound 4: 2.6-fold (0.41 log units) below; the range from low to high includes it.
By their numbers in this assay, from the lowest: compound 2; then compounds 3 and 4 (each within the scatter of the next); then compound 1.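

In this assay, 3,4,5-trimethoxyphenyl in place of 4-methoxyphenyl gives a 1.4-fold higher number from compound 3 to compound 4 (0.14 log units; within the scatter), so this place, sensitive to the earlier swaps, does not separate compound 3 and compound 4 despite the added heavy atoms and hydrogen-bond acceptors. The other two steps, an 18-fold higher number from compound 2 to compound 4 (1.26 log units; beyond the scatter) and a 2.2-fold lower number from compound 1 to compound 4 (0.35 log units; beyond the scatter), place the two methoxy-bearing compounds together, apart from both the 4-cyanophenyl and the 3-methylphenyl compounds. No evidence at hand accounts for any of these steps.

Open, on these data alone, is whether the low number of compound 2 goes with the nitrile itself: a nitro group or a carboxylic acid in place of the cyano on the aromatic carbon could fall near compound 2 or near compound 3 and compound 4. Also open, as far as these compounds go, is how far a methyl group in the place of the cyano would move the number, since compound 1 differs from compound 2 in both group and ring location.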